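Swapping an Ethyl for a Cyclohexyl on an Amide

The compounds below may be only part of what the source reports. "The series", "measured", "known", "first", "only" and "open" are said of these compounds alone.

Compound 1 `CCOC(=O)/C(C#N)=C/c1ccoc1` and compound 2 `CCNC(=O)/C(C#N)=C/c1ccoc1` share a core and differ only at the carbonyl carbon. In a functional assay on the whole organism (strain CD1) for inhibition, with Mus musculus as the target, with stated times of 15 min and 20 min, at a dose of 10 mg/kg by the subcutaneous route (on this read-out lower numbers stand for less inhibition and higher numbers for more inhibition at the one dose given (going by the name of the read-out)), compound 1 gives 55.9%, while compound 2 gives 31%. For the measured compounds named here, the move a number 24.9 percentage points lower from compound 1 to compound 2 (beyond the scatter) is the only measured step, and compound 2 holds the lower of the two numbers, with compound 1 as its only neighbour.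

Compound 3 `N#C/C(=C\c1ccoc1)C(=O)NC1CCCCC1` has not been measured yet. It differs from compound 2 in one place: cyclohexyl in place of ethyl on an amide-type nitrogen. Going by the values given here, the one measured step concerns a change at the carbonyl carbon, ethylamino in place of ethoxy, and tells nothing about what is carried on the amide-type nitrogen. Among the compounds with values here, no measured step bears on this change, so there is no basis for expecting a move beyond the scatter in either direction, and the estimate is kept wide.

In this assay compound 3 is expected to give 33%, within a range from 8% to 58%. That estimate means a step of a number 2 percentage points higher from compound 2 to compound 3 (within the scatter) is expected, essentially no change.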

Compound 3, a percentage reported as inhibition, in the whole organism at one dose (the size of the read-out at that dose, not a potency): 0%
Compound 3: the middle estimate sits 33 percentage points above what was measured; measured number outside the range, below it.
By their numbers in this assay, from the lowest: compound 3; then compound 2; then compound 1.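

In this assay, cyclohexyl in place of ethyl on the amide-type nitrogen gives a number 31 percentage points lower from compound 2 to compound 3 (beyond the scatter), so this position is not indifferent to the group it carries. Compound 3 gives 0%, which means that at the one dose tested, the inhibition seen with ethyl on this nitrogen is not retained with cyclohexyl, a group of 6 heavy atoms with one six-membered non-aromatic ring in place of 2 heavy atoms and no ring. No measurement here goes beyond the read-out itself, so the data offer no explanation for the drop, and the added carbon atoms cannot be separated from the ring as the feature that matters.

On these data alone, with only ethyl and cyclohexyl compared on this nitrogen, the shape of the trend remains open, since two groups show a difference but not where along the way the number falls. A propyl chain would test a modest extension without a ring, while a cyclopropyl ring would test a ring with far fewer carbons than cyclohexyl, and together they would begin to separate chain length from ring.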